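Carbamate in place of ester on the side chain

A few compounds are considered here, and "the series" means these few. Any claim that something is new, unique, unknown or untested is made for them only; others in the source may bear on it.

Compound 1 `COc1cc(C(=O)N2CCN(C(=O)c3cc(OC)c(OC)c(OC)c3)C(COC(=O)C3CCCCC3)C2)cc(OC)c1OC` holds the lowest number in a functional assay (Oryctolagus cuniculus) for inhibition of platelet-activating factor receptor (Cavia porcellus) (a higher number here means a weaker inhibitor, a lower number a stronger inhibitor), where compound 1 gives 290 nM. Compound 2 `COc1cc(N2CCN(c3cc(OC)c(OC)c(OC)c3)CC2)cc(OC)c1OC` gives 12500 nM in this assay, and the two values stand well apart. Within the data shown here, compound 3 `COc1cc(C(=O)N2CCN(C(=O)c3cc(OC)c(OC)c(OC)c3)C(COC(=O)NC(C)C(C)C)C2)cc(OC)c1OC` differs from compound 1 by (1,2-dimethylpropyl)amino in place of cyclohexyl on a carbonyl carbon, a change for which no measured step exists in this set. With nothing of this kind measured, the expected step is a 1.4-fold higher number from compound 1 to compound 3 (0.14 log units; within the scatter), small and possibly within the scatter. For compound 3 the estimate in this assay is 400 nM, with a range from 120 nM to 1500 nM.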

Compound 3, half-maximal inhibitory concentration: 80 nM
Compound 3: the middle estimate sits 5.0-fold (0.70 log units) above what was measured; the whole stated range lies above it.
By their numbers in this assay, from the lowest: compound 3; then compound 1; then compound 2.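

In this assay, (1,2-dimethylpropyl)amino in place of cyclohexyl on a carbonyl carbon gives a 3.6-fold lower number from compound 1 to compound 3 (0.56 log units; beyond the scatter), so this side-chain position accepts a carbamate in place of the ester, and the open-chain group with its one hydrogen-bond donor gives the lower number here. This single pair changes the ring, the nitrogen and the donor count at once and cannot separate them. Nothing available explains the drop. Open, as far as these compounds go, is whether cyclohexylamino, which keeps the ring alongside the nitrogen, matches (1,2-dimethylpropyl)amino. From the compounds shown here alone, an unbranched pentylamino chain at the same carbonyl carbon is equally open.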